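Hydroxy Added to a Methoxyphenyl Ring: Antiproliferative Outlook

The source may report more compounds than this note shows. Statements on the series, on what has been measured and on what is new or still open speak of the compounds shown alone.

Measured compounds:
compound 1 `COc1cc(-n2cnc3ccc(-c4cccc(C)c4C)cc32)cc(OC)c1OC`: 9250 nM
compound 2 `COc1ccc(-c2ccc3ncn(-c4cc(OC)c(OC)c(OC)c4)c3c2)cc1`: > 10000 nM
compound 3 `COc1cc(-n2cnc3ccc(-c4ccc(C)cc4)cc32)cc(OC)c1OC`: 1940 nM

Three compounds sharing one core differ only in the aryl group on an aromatic carbon. In a functional assay on A549 cells (Homo sapiens) for antiproliferative activity, read by MTT assay, with a stated time of 72 h (a lower number here means a stronger inhibitor, a higher number a weaker inhibitor), compound 1 gives 9250 nM. Compound 3, with 4-methylphenyl in place of 2,3-dimethylphenyl, gives 1940 nM, a change of a 4.8-fold lower number from compound 1 to compound 3 (0.68 log units; beyond the scatter). For compound 2 the assay reports only a limit, > 10000 nM, so its true standing is not known beyond that boundary. The step of an at least 1.0-fold higher number from compound 1 to compound 2 (0.03 log units; that floor lies within the scatter) and the step of an at least 5.1-fold lower number from compound 2 to compound 3 (0.71 log units; beyond the scatter) are accordingly bounded on one side only.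

Compound 4 `COc1ccc(-c2ccc3ncn(-c4cc(OC)c(OC)c(OC)c4)c3c2)cc1O` arises from compound 2 through (hydroxy in place of hydrogen on an aromatic carbon). No measured step involves a hydroxy group, so the shown steps bear on this change only indirectly: they show that the substituent pattern on this aryl ring can move the number by an at least 5.1-fold lower number from compound 2 to compound 3 (0.71 log units; beyond the scatter), while leaving the effect of a hydroxy open. Compound 4 is therefore expected to give 5000 nM, within 800 nM to 20000 nM, a step estimated as an at least 2.0-fold lower number from compound 2 to compound 4 (0.30 log units; that floor lies within the scatter), with a real chance that only a limit is reported again.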

Compound 4, half-maximal inhibitory concentration: 200 nM
The estimate for compound 4 lay 25-fold (1.40 log units) above the measured number; measured number outside the range, below it.
By their numbers in this assay, from the lowest: compound 4; then compound 3; then compound 1. At a limit, above all of these: compound 2.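

Within the data shown here, on the 4-methoxyphenyl ring, one hydroxy ortho to a methoxy group moves the number in this assay further than any change among the earlier compounds, which varied only methyl and methoxy groups on this aryl ring: an at least 50-fold lower number from compound 2 to compound 4 (1.69 log units; beyond the scatter). Compound 2 stands only at a limit, so the size of this step is a floor, because the true value lies beyond that limit: the limit of > 10000 nM in this assay, at which 1 of the 4 values shown sits. The 3-hydroxy-4-methoxyphenyl group also gives a lower number than either methyl-bearing aryl group, with a 9.7-fold lower number from compound 3 to compound 4 (0.99 log units; beyond the scatter) and a 46-fold lower number from compound 1 to compound 4 (1.67 log units; beyond the scatter).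

The compounds shown leave open whether an amine or a fluorine in place of the hydroxy would give a similar number. They also leave open whether a hydroxy would act the same way on a ring lacking the methoxy group.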